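Phenyl in place of 1-methylpyrrolidin-2-yl on a carbonyl carbon

The compounds below may be only part of what the source reports. "The series", "measured", "known", "first", "only" and "open" are said of these compounds alone.

In a functional assay on COR-L23 cells (Homo sapiens) for antiproliferative activity, read by CellTiter-Glo, with a stated time of 4 days (on this read-out lower numbers stand for stronger inhibition and higher numbers for weaker inhibition), compound 3 `C[C@H](NC(=O)[C@@H]1CCCN1C)c1ccc(NC(=O)[C@H]2C[C@@H]2c2cccnc2)cc1` gives 11 nM, the lowest of the three measured numbers, against compound 2 `COCC(=O)N[C@@H](C)c1ccc(NC(=O)[C@H]2C[C@@H]2c2cccnc2)cc1` at 111 nM and compound 1 `O=C(N[C@@H](CO)c1ccc(NC(=O)[C@H]2C[C@@H]2c2cccnc2)cc1)c1ccccc1` at 630 nM. Compound 4 `C[C@H](NC(=O)c1ccccc1)c1ccc(NC(=O)[C@H]2C[C@@H]2c2cccnc2)cc1` carries phenyl in place of 1-methylpyrrolidin-2-yl on a carbonyl carbon. For the measured compounds named here, one measured step bears directly on this place: a 10-fold lower number from compound 2 to compound 3 (1.00 log units; beyond the scatter), where 1-methylpyrrolidin-2-yl replaced methoxymethyl. Compound 1 also carries benzoyl but differs from compound 4 elsewhere, so it is only a loose guide. A step of similar size towards a higher number is therefore expected in this assay, an estimated 8.2-fold higher number from compound 3 to compound 4 (0.91 log units; beyond the scatter). Compound 4 is expected at 90 nM, within an estimated range from 25 nM to 350 nM.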

Compound 4, half-maximal inhibitory concentration: 8 nM
Estimate against measurement, compound 4: 11-fold (1.05 log units) above; the measured number lies below the stated range.
By their numbers in this assay, from the lowest: compounds 4 and 3 (each within the scatter of the next); then compound 2; then compound 1.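

In this assay, the change from 1-methylpyrrolidin-2-yl to phenyl on a carbonyl carbon gives a 1.4-fold lower number from compound 3 to compound 4 (0.14 log units; within the scatter), so a basic-looking amine ring is not required here: the aromatic carbon ring serves equally well. Phenyl in place of methoxymethyl gives a 14-fold lower number from compound 2 to compound 4 (1.14 log units; beyond the scatter). With benzoyl kept, hydrogen in place of hydroxy on the saturated chain carbon gives a 79-fold lower number from compound 1 to compound 4 (1.90 log units; beyond the scatter), which places the gap at that chain carbon, not in the benzoyl. Nothing available here explains these steps. On these data alone, whether a fluorophenyl or a carboxylic acid on this carbonyl carbon would hold the number remains open.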